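The compounds below may be only part of what the source reports. "The series", "measured", "known", "first", "only" and "open" are said of these compounds alone.

The shared core appears in compound 1 `Cc1ccccc1-n1nc(C)c2c1NC(=O)[C@H](C)S[C@@H]2c1ccc(-c2ccccc2)cc1`, which in an assay on isolated protein for agonist activity at Bile acid receptor (Homo sapiens), read by AlphaScreen, with a stated time of 30 min (a lower number here means that less compound is needed, a higher number that more compound is needed for the effect), gives 990 nM. Compound 2 `Cc1ccccc1-n1nc(C)c2c1NC(=O)[C@H](C)S[C@@H]2c1ccc(-c2ccsc2)cc1` carries a thiophen-3-yl in place of the phenyl, and in this assay compound 2 gives 1400 nM; the step of a 1.4-fold higher number from compound 1 to compound 2 (0.15 log units; within the scatter) is within the scatter. Compound 3 `Cc1ccccc1-n1nc(C)c2c1NC(=O)[C@H](C)S[C@@H]2c1ccc(-c2ccc(C(=O)O)cc2)cc1` carries a 4-carboxyphenyl in the same position, and in this assay compound 3 is reported as "not active" (no number reported), so no single number stands for it, and it can only be placed as weaker than compound 1 and compound 2.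

Compound 4 `COc1ccccc1Oc1ccc([C@H]2S[C@@H](C)C(=O)Nc3c2c(C)nn3-c2ccccc2C)cc1` differs from compound 3 in one place: 2-methoxyphenoxy in place of 4-carboxyphenyl on an aromatic carbon. Among the measured compounds shown here, the only measured step, from compound 1 to compound 2, changes a different group and does not involve the 4-carboxyphenyl, so no measured step bears directly on this change. What the data do show is that compound 1 and compound 2, which lack the carboxylic acid, both give numbers in this assay while compound 3 does not, so a return to a measurable value is expected in this assay for compound 4, though without a measured step its size is uncertain. Compound 4 is estimated at 1800 nM, with a range from 400 nM to 8000 nM.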

Compound 4, half-maximal effective concentration: 1700 nM
Compound 4: middle estimate off by 1.1-fold (0.02 log units), on the high side, and the stated range covers the measured number.
By their numbers in this assay, from the lowest: compounds 1, 2 and 4 (each within the scatter of the next).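

In this assay, the place on the aromatic ring para to a large group also accepts a 2-methoxyphenoxy: the steps of a 1.2-fold higher number from compound 2 to compound 4 (0.08 log units; within the scatter) and a 1.7-fold higher number from compound 1 to compound 4 (0.23 log units; within the scatter) both stay within the usual scatter, so this group cannot be told apart from thiophen-3-yl or phenyl here. The comparison with the 4-carboxyphenyl is sharper, since both groups have 9 heavy atoms and one six-membered aromatic ring, yet compound 3 is reported as "not active" (no number reported) while compound 4 gives 1700 nM, so the heavy-atom count alone does not separate a compound with a number from one without. No measurement shown explains this difference between the two groups.

Going by these compounds, whether an amine or a hydroxyl in this place would also give a number remains open, as does the result for a carboxylic acid held further from the ring on a longer chain. All four compounds also share the same core, so these results do not show whether the tolerance seen in this place would hold if another part of the molecule were changed.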